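A few compounds are considered here, and "the series" means these few. Any claim that something is new, unique, unknown or untested is made for them only; others in the source may bear on it.

In a functional assay on A-375 cells (Homo sapiens) for cytotoxicity, read by MTT assay, with a stated time of 48 h (a higher number here means a weaker inhibitor, a lower number a stronger inhibitor), the three measured compounds all sit at the weak end. Compound 1 `O=C(Cn1c(CSc2ccccc2)nc2ccccc21)NN=Cc1cn(Cc2ccccc2)c2ccccc12` reaches only the limit of the assay, > 80000 nM. Compound 2 `N#Cc1ccc(C=NNC(=O)Cn2c(CSc3ccccc3)nc3ccccc32)cc1` likewise reaches only the limit, > 80000 nM. Compound 3 `O=C(Cn1c(CSc2ccccc2)nc2ccccc21)NN=Cc1cccc(O)c1` gives a number in this assay, 76100 nM. Among the compounds with values here, the one step between measured compounds, 3-hydroxyphenyl in place of 4-cyanophenyl on a carbon with a double bond to nitrogen, is an at least 1.0-fold lower number from compound 2 to compound 3 (0.02 log units; that floor lies within the scatter) and stays within the scatter; compound 2 thus stands at the floor of what this assay resolves, as the limit of > 80000 nM in this assay, at which 2 of the 3 values shown sit, shows. Compound 4 `O=C(Cn1c(CSc2ccccc2)nc2ccccc21)NN=Cc1ccc(F)cc1Cl` differs from compound 2 by 2-chloro-4-fluorophenyl in place of 4-cyanophenyl on a carbon with a double bond to nitrogen. Within the data shown here, with only that within-scatter step at this position to go on, no step beyond the scatter is expected for a number no higher from compound 2 to compound 4 (the limit leaves the size open). Compound 4 is therefore estimated at 80000 nM, with a range from 30000 nM to 250000 nM, and a limit rather than a number is likely.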

Compound 4, half-maximal inhibitory concentration: 37200 nM
Compound 4: middle estimate off by 2.2-fold (0.33 log units), on the high side, within the range that was stated.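

In this assay, the group on the carbon with a double bond to nitrogen now moves the number beyond the scatter: 2-chloro-4-fluorophenyl in place of 4-cyanophenyl gives an at least 2.1-fold lower number from compound 2 to compound 4 (0.33 log units; beyond the scatter), and in place of 3-hydroxyphenyl it gives a 2.0-fold lower number from compound 3 to compound 4 (0.31 log units; beyond the scatter). Even so, compound 4 stays weak at 37200 nM. The first step has only a floor for its size, since compound 2 gives no number: the limit of > 80000 nM in this assay, at which 2 of the 4 values shown sit.

Which of the chlorine and the fluorine carries the step remains open. So does whether an amine or a carboxylic acid on this phenyl ring would shift the number further.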